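Swapping the Furan Ring for Pyridine on a Shared Core

The source may report more compounds than this note shows. Statements on the series, on what has been measured and on what is new or still open speak of the compounds shown alone.

Compound 1 `Oc1ccccc1-c1cc(-c2ccco2)cc(-c2ccccc2O)n1`: > 50000 nM
Compound 2 `Oc1cccc(-c2cc(-c3ccco3)cc(-c3ccccc3O)n2)c1`: 1790 nM
Compound 3 `Oc1cccc(-c2cc(-c3ccco3)cc(-c3cccc(O)c3)n2)c1`: 2150 nM

All three compounds were tested in a functional assay on DU-145 cells (Homo sapiens) for cytotoxicity, read by CCK-8 assay; a higher number here means a weaker inhibitor, a lower number a stronger inhibitor. For compound 1 the result is a limit of the assay rather than a number (the limit of > 50000 nM in this assay, at which 1 of the 3 values shown sits). Among the two numbers, compound 2 has the lowest, and compound 3 sits so close that the step of a 1.2-fold higher number from compound 2 to compound 3 (0.08 log units; within the scatter) falls within the scatter, so the two cannot be ranked. By contrast, the step of an at least 27-fold lower number from compound 1 to compound 2 (1.44 log units; beyond the scatter) is large.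

Compound 4 `Oc1cccc(-c2cc(-c3cccnc3)cc(-c3ccccc3O)n2)c1` differs from compound 2 in a single place: pyridin-3-yl in place of furan-2-yl on an aromatic carbon. Neither measured step speaks to this change. Both of them exchange one hydroxyphenyl group for another, leaving the furan untouched, so they offer no guide to what replacing the furan with pyridine does. Without any measured precedent for this position, the expectation is a step from compound 2 to compound 4 that stays within the scatter, a 1.1-fold higher number from compound 2 to compound 4 (0.05 log units; within the scatter), with a wide margin of uncertainty in either direction. Compound 4 is therefore estimated at 2000 nM in this assay, with a likely range from 600 nM to 7000 nM.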

Compound 4, half-maximal inhibitory concentration: 5580 nM
For compound 4 the middle estimate is 2.8-fold (0.45 log units) below the measured one; the range from low to high includes it.
By their numbers in this assay, from the lowest: compounds 2 and 3 (each within the scatter of the next); then compound 4. At a limit, above all of these: compound 1.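

Among these compounds, this result gives the first reading at the position opposite the ring nitrogen, where the earlier steps left the furan-2-yl group untouched. In this assay, pyridin-3-yl in place of furan-2-yl gives a 3.1-fold higher number from compound 2 to compound 4 (0.49 log units; beyond the scatter), so this position does respond to a change of ring, though only modestly. The furan-2-yl group is also not required for a measured number, since compound 4, which carries a six-membered aromatic ring there instead, still gives 5580 nM, yet nothing in the data shown explains why the swap moves the number in this direction.

As far as these compounds go, with a single replacement at this position, it remains open whether the step comes from the change in ring size, from the exchange of the ring oxygen for a ring nitrogen, or from both, and a plain phenyl ring or a pyridin-4-yl group would help to separate these. Also open, from the compounds shown here alone, is whether the same swap gives a similar step on the core of compound 3, and whether a group other than an aromatic ring, such as an amine or a carboxylic acid, can sit at this position.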